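Succinate versus acetate esters in a triterpenoid series

The compounds below may be only part of what the source reports. "The series", "measured", "known", "first", "only" and "open" are said of these compounds alone.

Compound 1 `CC(=O)O[C@H]1CC[C@]2(C)[C@H](CC[C@@](C)(O)[C@H]2CC[C@@H]2C(C)=CC[C@H]3[C@H](CC[C@]3(C)O)C2(C)C)OC1(C)C` gives 47900 nM in a functional assay on MCF7 cells (Homo sapiens) for antiproliferative activity, read by MTT assay, with a stated time of 72 h; a lower number here means a stronger inhibitor, a higher number a weaker inhibitor.
Compound 2 `CC1=CC[C@H]2[C@H](CC[C@]2(C)O)C(C)(C)[C@@H]1CC[C@H]1[C@]2(C)CC[C@H](OC(=O)CCC(=O)O)C(C)(C)O[C@H]2CC[C@@]1(C)O` gives only > 50000 nM in this assay, which is a limit of the assay and not a number.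
Compound 3 `CC(=O)O[C@H]1CC[C@]2(C)[C@H](CC[C@@](C)(O)[C@H]2CC[C@@H]2C(C)=CC[C@@H]3C(C)=CC[C@@H]3C2(C)C)OC1(C)C` gives 43500 nM in this assay.

Compound 1 and compound 2 share a core and differ by carboxymethyl in place of hydrogen on a saturated chain carbon bound to a carbonyl carbon. This change made an at least 1.0-fold higher number from compound 1 to compound 2 (0.01 log units; that floor lies within the scatter), and that floor rests on (the limit of > 50000 nM in this assay, at which 1 of the 3 values shown sits). Compound 3 carries a different core from compound 1; the difference between the two cores is not broken down here. In this assay the value of compound 3 and that of compound 1 sit within the scatter of each other, so nothing can be said about their order.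

Compound 4 `CC1=CC[C@H]2[C@@H]1CC=C(C)[C@@H](CC[C@H]1[C@]3(C)CC[C@H](OC(=O)CCC(=O)O)C(C)(C)O[C@H]3CC[C@@]1(C)O)C2(C)C` is not yet measured. It stands to compound 3 as compound 2 stands to compound 1: it differs by carboxymethyl in place of hydrogen on a saturated chain carbon bound to a carbonyl carbon, the same change made at the same kind of position. On the strength of the earlier step of an at least 1.0-fold higher number from compound 1 to compound 2 (0.01 log units; that floor lies within the scatter), which reached (the limit of > 50000 nM in this assay, at which 1 of the 3 values shown sits), the step in this assay is expected to be a 1.5-fold higher number from compound 3 to compound 4 (0.17 log units; within the scatter). Compound 4 is therefore estimated at 65000 nM in this assay, with an expected range from 38000 nM to 160000 nM, and it is likely that the assay again reports only a limit rather than a number.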

Compound 4, half-maximal inhibitory concentration: > 50000 nM
Compound 4: no number, only a limit; the forecaster's own chance of this, stated with the estimate: 70%; the middle value lies beyond the limit too.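

In this assay compound 4 gives > 50000 nM, which is a limit of the assay and not a number. Carried from one core to the other, carboxymethyl in place of hydrogen on a saturated chain carbon bound to a carbonyl carbon, which turns acetoxy into ((2-carboxyethyl)carbonyl)oxy, gives an at least 1.1-fold higher number from compound 3 to compound 4 (0.06 log units; that floor lies within the scatter), so neither core shows a measured strengthening from this change, while the floor is too small to establish a weakening. The result therefore does not show how large the step is on either core, nor whether the change carries over with the same size: the same change on two cores in this assay, an at least 1.0-fold higher number (0.01 log units; that floor lies within the scatter) from compound 1 to compound 2 and an at least 1.1-fold higher number (0.06 log units; that floor lies within the scatter) from compound 3 to compound 4; the limit leaves it open whether they differ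

The compounds shown leave open whether a methyl ester of the terminal carboxylic acid, an amine at the end of the chain, or a longer chain would bring either core to a number rather than a limit in this assay. Also open, going by these compounds, is what a plain hydroxyl in place of the acetoxy would give on these two cores.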